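Swapping a Chlorinated Styryl Arm for a Trifluoromethoxy Biphenyl

The compounds below may be only part of what the source reports. "The series", "measured", "known", "first", "only" and "open" are said of these compounds alone.

Of the compounds shown here, three have so far been tested in an assay on isolated protein with Bile acid receptor (Homo sapiens) as the target; a lower number here means that less compound is needed, a higher number that more compound is needed for the effect. Compound 1, with the structure `COC(=O)/C=C/c1cccc(N(Cc2cc(OC)cc(OC)c2)C(=O)C2CCCCC2)c1`, gives 603 nM. Compound 3, with the structure `COC(=O)/C=C/c1cccc(N(Cc2ccc(/C=C/c3cccc(F)c3)cc2)C(=O)NC(C)C)c1`, gives 468 nM. Compound 2, with the structure `COC(=O)/C=C/c1cccc(N(Cc2ccc(/C=C/c3c(Cl)cccc3Cl)cc2)C(=O)C2CCCCC2)c1`, gives 151 nM, the lowest of the three numbers; its gap to compound 3 and its gap to compound 1 both lie beyond the usual scatter, so compound 2 stands as the most potent of the measured set in this assay.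

Compound 4, with the structure `COC(=O)/C=C/c1cccc(N(Cc2ccc(-c3ccc(OC(F)(F)F)cc3)cc2)C(=O)C2CCCCC2)c1`, has not yet been measured. It differs from compound 2 in one place: 4-(trifluoromethoxy)phenyl in place of 2-(2,6-dichlorophenyl)ethenyl on an aromatic carbon. The new group sits on an aromatic carbon, para to a large group, where the dichlorophenyl-ethenyl arm stood before.

For the measured compounds named here, no pair of measured compounds differs in exactly this way, so the size of the step cannot be read from the data. The three measured values span only a modest range, and the change keeps a large aromatic substituent in the same position. Compound 4 is therefore expected to land near compound 2, perhaps somewhat weaker, with an expected value of 300 nM in this assay and a range from 100 nM to 900 nM. The expected step from compound 2 to compound 4 is a 2.0-fold higher number from compound 2 to compound 4 (0.30 log units; within the scatter).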

Compound 4, half-maximal effective concentration: 263 nM
The estimate for compound 4 lay 1.1-fold (0.06 log units) above the measured number; low and high end bracket the measured number.
By their numbers in this assay, from the lowest: compounds 2, 4, 3 and 1 (each within the scatter of the next, the first and the last beyond it).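

At this aromatic carbon, para to a large group, 4-(trifluoromethoxy)phenyl in place of 2-(2,6-dichlorophenyl)ethenyl gives a 1.7-fold higher number from compound 2 to compound 4 (0.24 log units; within the scatter), so this assay does not separate the two arms. For the compounds shown here, this is the first direct comparison at this position, and the two groups differ in more than one way: the double bond outside aromatic rings and both chlorine atoms leave, while an oxygen atom, three fluorine atoms and a hydrogen-bond acceptor enter. In this single pair, then, the position accepts either large aromatic arm without a change beyond the scatter, although nothing shown explains why the two numbers stay so close.

On these data alone, what remains open is how much of the arm matters, since one pair cannot separate the contributions of the lost double bond, the lost chlorine atoms and the new trifluoromethoxy group. An unsubstituted phenyl, or an amine or a carboxylic acid in place of the trifluoromethoxy group, would test whether this position stays as accommodating with a smaller or a charged group.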